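Fluoro in Place of Hydrogen on the Phenyl Ring

The source may hold more compounds than are shown below. What is called first, only, known or untested is meant among the compounds shown, and "the series" means these compounds.

Compound 1, `C=C(Br)C(=O)Nc1cccc(-c2cn3nc(-c4ccc(OCC)cc4)sc3n2)c1`: 790 nM in a functional assay on L1210 cells (Mus musculus) for inhibition, read by cell counting, with a stated time of 2 days; on this read-out higher numbers stand for weaker inhibition and lower numbers for stronger inhibition
Compound 2, `C=C(Br)C(=O)Nc1cccc(-c2cn3nc(CCc4ccccc4)sc3n2)c1`: 2200 nM
Compound 3, `C=C(Br)C(=O)Nc1cccc(-c2cn3nc(-c4ccccc4)sc3n2)c1`: 600 nM

Compound 3 has the lowest number of the three measured compounds. Its gap to compound 1 is within the scatter (a 1.3-fold lower number from compound 1 to compound 3 (0.12 log units; within the scatter)), while its gap to compound 2 is beyond it (a 3.7-fold lower number from compound 2 to compound 3 (0.56 log units; beyond the scatter)). Compound 4, `C=C(Br)C(=O)Nc1cccc(-c2cn3nc(-c4ccc(F)cc4)sc3n2)c1`, differs from compound 3 by fluoro in place of hydrogen on an aromatic carbon. Among the compounds with values here, the one measured step that bears on this change concerns the same phenyl ring: removing ethoxy from it, a 1.3-fold lower number from compound 1 to compound 3 (0.12 log units; within the scatter), stayed within the scatter. A single fluoro entering on that ring is therefore expected to give no step beyond the scatter, no change at the digits printed from compound 3 to compound 4 (within the scatter). Compound 4 is estimated at 600 nM, with a range from 300 nM to 1200 nM.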

Compound 4, half-maximal inhibitory concentration: 250 nM
Estimate against measurement, compound 4: 2.4-fold (0.38 log units) above; the whole stated range lies above it.
By their numbers in this assay, from the lowest: compound 4; then compounds 3 and 1 (each within the scatter of the next); then compound 2.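

In this assay, this place on the phenyl ring, para to a large group, turns out to respond to a single small atom: fluoro gives a 2.4-fold lower number from compound 3 to compound 4 (0.38 log units; beyond the scatter), whereas removing ethoxy there had stayed within the scatter. Set against ethoxy at that same place, fluoro gives a 3.2-fold lower number from compound 1 to compound 4 (0.50 log units; beyond the scatter), so the group at this place does matter. The 4-fluorophenyl group in place of phenethyl gives an 8.8-fold lower number from compound 2 to compound 4 (0.94 log units; beyond the scatter), leaving compound 4 with the lowest number of the four. Nothing shown explains why fluoro lowers the number. From the compounds shown here alone, whether chloro or methoxy at this place would do the same, or fluoro elsewhere on the ring, stays open.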